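The compounds below may be only part of what the source reports. "The series", "measured", "known", "first", "only" and "open" are said of these compounds alone.

Among the compounds with values here, compound 3 `CCCCCCCCCCCCNC(=O)[C@@H](NS(=O)(=O)c1ccc(C)cc1)[C@@H](C)O` holds the only plain number in a functional assay on HepG2 cells (Homo sapiens) for cytotoxicity, read by MTT assay, with a stated time of 48 h; on this read-out lower numbers stand for stronger inhibition and higher numbers for weaker inhibition: compound 3 gives 25800 nM. Compound 1 `CCCCCCCCCCCCNC(=O)[C@@H](NC(=O)c1ccccc1)[C@@H](C)O` reaches only a limit of this assay, > 400000 nM. Compound 2 `CCCCCCCCCCCCNC(=O)[C@@H](NC(=O)/C=C/c1ccccc1)[C@@H](C)O` likewise stops at a limit, > 200000 nM. The move to the sulfonamide was the large step in the set: an at least 15-fold lower number from compound 1 to compound 3 (1.19 log units; beyond the scatter) and an at least 7.7-fold lower number from compound 2 to compound 3 (0.88 log units; beyond the scatter), while a step that the two limits leave unreadable from compound 1 to compound 2. Compound 4 `CCCCCCCCCCCCNC(=O)[C@@H](NS(=O)(=O)c1cccs1)[C@@H](C)O` keeps that sulfonamide and changes only the ring on it: thiophen-2-yl in place of 4-methylphenyl on a sulfonyl sulfur. Within the data shown here, no measured step alters the ring on the sulfonyl sulfur, so the two readable steps do not bear directly on this change; both concern the sulfonamide itself, which compound 4 retains. For compound 4 the expected step is a 1.4-fold higher number from compound 3 to compound 4 (0.13 log units; within the scatter), none beyond the scatter. Compound 4 is estimated at 35000 nM, between 12000 nM and 100000 nM.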

Compound 4, half-maximal inhibitory concentration: 25900 nM
Compound 4: the middle estimate sits 1.4-fold (0.13 log units) above what was measured; low and high end bracket the measured number.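

In this assay, the two rings on the sulfonyl sulfur read alike: a 1.0-fold higher number from compound 3 to compound 4 (0.00 log units; within the scatter). A second sulfonamide now shows the separation from the amides, so it no longer rests on compound 3 alone: an at least 7.7-fold lower number from compound 2 to compound 4 (0.88 log units; beyond the scatter), and an at least 15-fold lower number from compound 1 to compound 4 (1.18 log units; beyond the scatter). Nothing shown bears on a cause for these steps.

Open, going by these compounds, is whether a phenyl ring carrying an amine or a carboxylic acid, or a methyl group in place of the ring on the sulfonyl sulfur, would stay at this level. Also open, on these data alone, is how a shorter or longer chain in place of the one shared by all four compounds would read.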